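The source may hold more compounds than are shown below. What is called first, only, known or untested is meant among the compounds shown, and "the series" means these compounds.

Working notes on the series

Compound 3, `CCOC(=O)CN(C)C(=O)c1ccc(C(CC)(CC)c2ccc(OCC(O)C(C)(C)C)c(C)c2)n1CC`, gives 210 nM in an assay on HL-60 cells for agonist activity at vitamin D3 receptor (Homo sapiens), read by microscopy, with a stated time of 96 h; a lower number here means that less compound is needed, a higher number that more compound is needed for the effect. Compound 2, `C#CC(C)OC(=O)c1ccc(C(CC)(CC)c2ccc(OCC(=O)C(C)(C)C)c(C)c2)n1CC`, gives 210 nM in this assay, so compound 3 stands level with compound 2 at the digits shown. Compound 1, `CCOC(=O)CN(C)C(=O)c1ccc(C(CC)(CC)c2ccc(OCC(=O)C(C)(C)C)c(C)c2)n1CC`, is the common parent. In this assay compound 1 gives > 50000 nM, which is a limit of the assay and not a number (the limit of > 50000 nM in this assay, at which 1 of the 3 values shown sits).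

Compound 4 is `C#CCCOC(=O)c1ccc(C(CC)(CC)c2ccc(OCC(O)C(C)(C)C)c(C)c2)n1CC`. The change from compound 3 is (but-3-yn-1-yl)oxy in place of ((ethoxycarbonyl)methyl)(methyl)amino on a carbonyl carbon.

Going by the values given here, two measured steps bear on this. The exchange of the same ((ethoxycarbonyl)methyl)(methyl)amino group on the carbonyl carbon for an alkynyl-bearing oxy group gave an at least 230-fold lower number from compound 1 to compound 2 (2.37 log units; beyond the scatter). The change that compound 3 already carries, 1-hydroxy-2,2-dimethylpropyl for (tert-butyl)carbonyl, gave an at least 230-fold lower number from compound 1 to compound 3 (2.37 log units; beyond the scatter). Both changes separately bring the parent from a limit to the same number, so their combination in compound 4 is expected to hold that level or move to a lower number; the expected step is a 2.1-fold lower number from compound 3 to compound 4 (0.32 log units; beyond the scatter). Compound 4 is therefore estimated at 100 nM, within 20 nM to 600 nM.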

Compound 4, half-maximal effective concentration: 1030 nM
Compound 4: middle estimate off by 10-fold (1.01 log units), on the low side, outside the stated range (above it).
By their numbers in this assay, from the lowest: compounds 2 and 3 (each within the scatter of the next); then compound 4. At a limit, above all of these: compound 1.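

In this assay, with the 1-hydroxy-2,2-dimethylpropyl group held in place, (but-3-yn-1-yl)oxy on the carbonyl carbon gives a 4.9-fold higher number from compound 3 to compound 4 (0.69 log units; beyond the scatter), so on this background the ((ethoxycarbonyl)methyl)(methyl)amino group is the better of the two. This runs opposite to an at least 230-fold lower number from compound 1 to compound 2 (2.37 log units; beyond the scatter), a step made with a different alkynyl oxy group and with (tert-butyl)carbonyl in place, so the two changes that each helped compound 1 do not simply add. Compound 1 stands at a limit and not a number, which leaves the new step as the only one at this place with a number at both ends: the limit of > 50000 nM in this assay, at which 1 of the 4 values shown sits.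

The compounds shown leave open whether the higher number follows from the but-3-yn-1-yl chain itself or from its pairing with the hydroxy group. Also open, going by these compounds, is how a carboxylic acid or a simple dimethylamino group on that carbonyl carbon would read.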